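Shortening the aryl chain by one carbon

This account rests on a few compounds, and the source may have more. Where it says the series, first, only, none or still open, it means among the compounds named here.

Measured compounds:
compound 1 `CCCCCCC#Cc1cn(C/C=C/CN2C(=O)c3ccccc3C2=O)c(=O)[nH]c1=O`, 24000 nM
compound 2 `CCCCCc1ccc(C#Cc2cn(C/C=C/CN3C(=O)c4ccccc4C3=O)c(=O)[nH]c2=O)cc1`, 5600 nM

For the measured compounds named here, in a functional assay on MCF7 cells (Homo sapiens) for antiproliferative activity, read by MTT assay, with a stated time of 3 days (a higher number here means a weaker inhibitor, a lower number a stronger inhibitor), compound 2 gives 5600 nM, the lowest of the two numbers; the only other compound, compound 1, sits higher by a 4.3-fold lower number from compound 1 to compound 2 (0.63 log units; beyond the scatter). Compound 3 `CCCCc1ccc(C#Cc2cn(C/C=C/CN3C(=O)c4ccccc4C3=O)c(=O)[nH]c2=O)cc1` differs from compound 2 by hydrogen in place of methyl on a saturated chain carbon, four bonds along the chain from an aromatic carbon. Going by the values given here, no measured step concerns a change of chain length; the one known step swaps an alkyl chain for an aryl group, so it offers no direct guide. Such a small trimming is expected to leave this assay about unchanged, within the scatter, giving a 1.3-fold higher number from compound 2 to compound 3 (0.10 log units; within the scatter). Compound 3 is therefore estimated at 7000 nM, between 3000 nM and 16000 nM.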

Compound 3, half-maximal inhibitory concentration: 44000 nM
The estimate for compound 3 lay 6.3-fold (0.80 log units) below the measured number; measured number outside the range, above it.
By their numbers in this assay, from the lowest: compound 2; then compounds 1 and 3 (each within the scatter of the next).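

In this assay, the end of the chain on the aryl group proves sensitive: losing a single methyl, with no ring or hydrogen-bonding group involved, gives a 7.9-fold higher number from compound 2 to compound 3 (0.90 log units; beyond the scatter). The gain from swapping hexyl for an aryl group therefore does not come from the aryl group alone, since 4-butylphenyl in place of hexyl gives only a 1.8-fold higher number from compound 1 to compound 3 (0.26 log units; within the scatter), which lies within the scatter. Nothing shown here explains the size of this step.

As far as these compounds go, whether a longer chain such as 4-hexylphenyl would lower the number further remains open. So does the effect of an amine at the chain end.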